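Pyrazole series: methoxy for trifluoromethyl on the aryl ring

The source may hold more compounds than are shown below. What is called first, only, known or untested is meant among the compounds shown, and "the series" means these compounds.

Measured compounds
- Compound 1 `Nc1ncnc2c1cnn2-c1ccc(C(F)(F)F)cc1` — a functional assay on MCF7 cells (Homo sapiens) for inhibition, with a stated time of 48 h; on this read-out higher numbers stand for weaker inhibition of growth and lower numbers for stronger inhibition of growth: "not determined" (no result reported)
- Compound 2 `N#Cc1cnn(-c2ccc(C(F)(F)F)cc2)c1N` — this assay : > 150000 nM

Compound 1 stands without a number in this assay; its entry is not determined. Compound 2 reaches only a limit in this assay, > 150000 nM, which is an assay limit and not a measured value. The single number shown for the pair is thus the line (the limit of > 150000 nM in this assay, at which 1 of the 2 values shown sits), where one of the two entries sits.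

Compound 3 `COc1ccc(-n2ncc3c(N)ncnc32)cc1` differs from compound 1 by a single change on the shared core, (methoxy in place of trifluoromethyl on an aromatic carbon). Among the measured compounds shown here, no measured step between two compounds carries this change, so its size rests on nothing in the numbers. On the expectation side, no shift beyond the usual scatter is assumed in either direction: the trifluoromethyl that leaves and the methoxy that enters are simply exchanged, and the core of compound 1 is kept whole.

For the measured compounds named here, with compound 1 not determined and the only number a limit, compound 3 is estimated to give about 20000 nM in this assay, within a range from 3000 nM to 150000 nM, with a fair chance that only a limit is reported.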

Compound 3, concentration for 50% growth inhibition: > 150000 nM
Compound 3: a limit, no number; the forecaster's own chance of this, stated with the estimate: 40%; at least 7.5-fold (0.87 log units) between middle value and limit.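

Among the compounds shown here, no step from compound 1 to compound 3 can be read in this assay, as compound 1 stands without a number there. Compound 3 gives only a limit of the assay, > 150000 nM. The series so far sits at one line: the limit of > 150000 nM in this assay, at which 2 of the 3 values shown sit.

The compounds shown leave open whether methoxy in place of trifluoromethyl changes growth inhibition at all.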